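Fewer ring nitrogens on the heteroaryl arm of compound 3

This account rests on a few compounds, and the source may have more. Where it says the series, first, only, none or still open, it means among the compounds named here.

Compound 1: `CCCCCCCCc1ccc(OCC(=O)Cn2ncc3cccnc32)cc1`, 1600 nM
Compound 2: `CCCCCCCCc1ccc(OCC(=O)Cn2cnc3cccnc32)cc1`, 410 nM
Compound 3: `CCCCCCCCc1ccc(OCC(=O)Cn2nnc3cccnc32)cc1`, 13 nM

In an assay on microsomes from brain for inhibition of Fatty-acid amide hydrolase 1 (Rattus norvegicus), read by fluorescence and HPLC, with a stated time of 60 min (a higher number here means a weaker inhibitor, a lower number a stronger inhibitor), compound 3 holds the lowest of the three numbers; its nearest neighbour is compound 2, with a 32-fold lower number from compound 2 to compound 3 (1.50 log units; beyond the scatter), and the furthest is compound 1, with a 120-fold lower number from compound 1 to compound 3 (2.09 log units; beyond the scatter). Compound 4 is `CCCCCCCCc1ccc(OCC(=O)Cn2ccc3ncccc32)cc1`. It differs from compound 3 in a group of 9 heavy atoms (7 carbon, 2 nitrogen; one five-membered aromatic ring with 1 hetero atom, one six-membered aromatic ring with 1 hetero atom) in place of a group of 9 heavy atoms (5 carbon, 4 nitrogen; one five-membered aromatic ring with 3 hetero atoms, one six-membered aromatic ring with 1 hetero atom), on a saturated chain carbon bound to a carbonyl carbon. Both measured steps into compound 3 bear on this change: they replaced a five-membered ring with fewer hetero atoms by one with three, and both lowered the number in this assay by a large amount. Compound 4 goes the other way and further, to a five-membered ring with only one hetero atom, so the number is expected to rise in this assay by a large margin, plausibly past the number of compound 1. Compound 4 is therefore estimated at 3000 nM, within 600 nM to 15000 nM. This corresponds to an expected step of a 230-fold higher number from compound 3 to compound 4 (2.36 log units; beyond the scatter).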

Compound 4, half-maximal inhibitory concentration: > 10000 nM
Compound 4 was reported as a limit; the forecaster's own chance of this, stated with the estimate: 15%; middle value at least 3.3-fold (0.52 log units) from the limit.
By their numbers in this assay, from the lowest: compound 3; then compound 2; then compound 1. At a limit, above all of these: compound 4.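

In this assay compound 4 stands at a limit of the assay, not at a number: the limit of > 10000 nM in this assay, at which 1 of the 4 values shown sits. With only 1 hetero atom in the five-membered aromatic ring, the steps are an at least 760-fold higher number from compound 3 to compound 4 (2.88 log units; beyond the scatter), an at least 24-fold higher number from compound 2 to compound 4 (1.38 log units; beyond the scatter) and an at least 6.2-fold higher number from compound 1 to compound 4 (0.79 log units; beyond the scatter), so the earlier trend toward lower numbers with more hetero atoms now has a low end, and all three steps lie beyond the scatter. The hetero atom count is not the whole story, though, since compounds 1 and 2 share the same count yet show a 3.9-fold lower number from compound 1 to compound 2 (0.59 log units; beyond the scatter).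

How far compound 4 really lies past the limit cannot be read from these data. As far as these compounds go, whether a tetrazole or a plain phenyl on the same saturated chain carbon would follow this trend also stays open.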